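The compounds below may be only part of what the source reports. "The series", "measured", "known", "first", "only" and "open" are said of these compounds alone.

In a functional assay on A-431 cells (Homo sapiens) for antiproliferative activity, read by MTT assay, with a stated time of 72 h (a higher number here means a weaker inhibitor, a lower number a stronger inhibitor), the measured compounds stand as follows:

Compound 1 `C#Cc1cccc(Nc2ncnc3ccc(NC(=S)Nc4ccc(S(N)(=O)=O)cc4)cc23)c1`: 15300 nM
Compound 2 `NS(=O)(=O)c1ccc(NC(=S)Nc2ccc3ncnc(Nc4ccc(Cl)c(C(F)(F)F)c4)c3c2)cc1`: 18200 nM
Compound 3 `NS(=O)(=O)c1ccc(NC(=S)Nc2ccc3ncnc(Nc4cccc(Br)c4)c3c2)cc1`: 20700 nM

Compound 3 holds the highest of the three numbers, yet the step of a 1.1-fold higher number from compound 2 to compound 3 (0.06 log units; within the scatter) and the step of a 1.4-fold higher number from compound 1 to compound 3 (0.13 log units; within the scatter) both fall within the scatter, so no order among the three can be read from them. Compound 4 `NS(=O)(=O)c1ccc(NC(=S)Nc2ccc3ncnc(Nc4ccc(C(F)(F)F)cc4)c3c2)cc1` differs from compound 3 by 4-(trifluoromethyl)phenyl in place of 3-bromophenyl on a nitrogen on an aromatic ring. For the measured compounds named here, the steps that bear on this change are the earlier exchanges on that same nitrogen, a 1.2-fold higher number from compound 1 to compound 2 (0.08 log units; within the scatter) and a 1.1-fold higher number from compound 2 to compound 3 (0.06 log units; within the scatter), neither of which moved the number beyond the scatter. On that basis no step beyond the scatter is expected in this assay for compound 4. Compound 4 is therefore estimated at 20000 nM, within a range from 9000 nM to 45000 nM. The expected step is a 1.0-fold lower number from compound 3 to compound 4 (0.01 log units; within the scatter).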

Compound 4, half-maximal inhibitory concentration: 18000 nM
Compound 4: the middle estimate sits 1.1-fold (0.05 log units) above what was measured, within the range that was stated.
By their numbers in this assay, from the lowest: compounds 1, 4, 2 and 3 (each within the scatter of the next).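

With 4-(trifluoromethyl)phenyl on the nitrogen, this assay still shows no step beyond the scatter: a 1.2-fold lower number from compound 3 to compound 4 (0.06 log units; within the scatter), a 1.0-fold lower number from compound 2 to compound 4 (0.00 log units; within the scatter) and a 1.2-fold higher number from compound 1 to compound 4 (0.07 log units; within the scatter). Losing the chloro of 4-chloro-3-(trifluoromethyl)phenyl thus leaves the number within the scatter, and all four groups on this nitrogen now stand within the scatter of one another. Nothing available explains this lack of separation.

Going by these compounds, whether a benzyl group or a morpholine on this nitrogen would move the number beyond the scatter remains open. So does the effect of changes elsewhere on the shared core.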